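Ethyl for methyl on the aniline nitrogen of compound 1

The compounds below may be only part of what the source reports. "The series", "measured", "known", "first", "only" and "open" are said of these compounds alone.

Going by the values given here, in a functional assay on HEK293 cells for agonist activity at Bile acid receptor (Homo sapiens), read by a luciferase reporter (on this read-out lower numbers stand for an effect already at smaller amounts and higher numbers for an effect only at larger amounts of compound), compound 1 `CN(Cc1ccc(C(=O)O)cc1)c1ccc(OCc2c(-c3c(Cl)cccc3Cl)noc2C2CC2)nc1C(F)(F)F` gives 6 nM, the lowest of the two numbers measured; its only neighbour is compound 2 `CN(Cc1ccc(C(=O)NCCS(=O)(=O)O)cc1)c1ccc(OCc2c(-c3c(Cl)cccc3Cl)noc2C2CC2)nc1C(F)(F)F`, which gives 925 nM in this assay. Among the compounds with values here, the one step on record, a 150-fold higher number from compound 1 to compound 2 (2.19 log units; beyond the scatter), concerns the (2-sulfoethyl)amino group replacing the hydroxy on the carbonyl carbon and says nothing about the nitrogen on the aromatic ring. Compound 3 `CCN(Cc1ccc(C(=O)O)cc1)c1ccc(OCc2c(-c3c(Cl)cccc3Cl)noc2C2CC2)nc1C(F)(F)F` differs from compound 1 by methyl in place of hydrogen on a saturated chain carbon bound to a nitrogen on an aromatic ring. Within the data shown here, no measured step bears on this change, so the size of the step in this assay is unsupported by data; the author expects a change of about a 1.7-fold higher number from compound 1 to compound 3 (0.22 log units; within the scatter), within the usual scatter, with a slight lean toward a higher number. Compound 3 is therefore estimated at 10 nM in this assay, in a range from 3 nM to 40 nM.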

Compound 3, half-maximal effective concentration: 113 nM
Estimate against measurement, compound 3: 11-fold (1.05 log units) below, outside the stated range (above it).
By their numbers in this assay, from the lowest: compound 1; then compound 3; then compound 2.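

Methyl in place of hydrogen on a saturated chain carbon bound to a nitrogen on an aromatic ring, which reads as methyl to ethyl, brings a 19-fold higher number from compound 1 to compound 3 (1.27 log units; beyond the scatter) in this assay and counts as a large step. Going by these compounds alone, the only earlier step lay at the carbonyl carbon, so this is the first sign that the number also responds at this second place in the molecule. A single added carbon is enough to move it beyond the scatter. Nothing at hand explains why this step is so large. 

From the compounds shown here alone, whether a longer chain such as propyl would raise the number further, or a bare hydrogen on that nitrogen would lower it, stays open. So does whether the step would keep its size with the (2-sulfoethyl)amino group on the carbonyl carbon.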